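Three analogues at the assay limit and a fourth to test

The source may report more compounds than this note shows. Statements on the series, on what has been measured and on what is new or still open speak of the compounds shown alone.

Compound 1 `COc1cccc(Cc2cc(-c3ccccc3)nn(CC(=O)Nc3ccc(Br)cc3)c2=O)c1`, compound 2 `COc1ccc(-c2cc(Cc3cccc(OC)c3)c(=O)n(CC(=O)Nc3ccc(F)cc3)n2)cc1` and compound 3 `COc1ccc(Cc2cc(-c3ccc(F)cc3)nn(CC(=O)Nc3ccc(Br)cc3)c2=O)cc1` share one core and differ only in their aryl groups. In a functional assay on HL-60 cells (Homo sapiens), read by calcium flux (on this read-out higher numbers stand for an effect only at larger amounts of compound and lower numbers for an effect already at smaller amounts), compound 1 gives > 50000 nM, which is a limit of the assay and not a number. In this assay compound 2 likewise gives only the limit > 50000 nM. In this assay compound 3 also reaches only the limit > 50000 nM. Within the data shown here, compound 2 thus stands at the limit of > 50000 nM in this assay, at which 3 of the 3 values shown sit, and no step between measured compounds is available. Compound 4 `COc1cccc(Cc2cc(-c3ccc(F)cc3)nn(CC(=O)Nc3ccc(F)cc3)c2=O)c1` differs from compound 2 by fluoro in place of methoxy on an aromatic carbon. With every measured compound at the limit, no step beyond the scatter is expected. Compound 4 is expected to give 80000 nM, within a range of 20000 nM to 300000 nM. This corresponds to an expected step that the limit leaves unreadable from compound 2 to compound 4.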

Compound 4, half-maximal effective concentration: > 50000 nM
Compound 4 ended at the assay's limit (the forecaster's own chance of this, stated with the estimate: 85%); the middle value is on the limit's open side.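

In this assay compound 2 and compound 4 both stay at a limit of the assay, so no step between them can be read: the limit of > 50000 nM in this assay, at which 4 of the 4 values shown sit.

The compounds shown leave open which change to the shared core, if any, gives a readable half-maximal effective concentration.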